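Swapping Iodo for Bromo on a Sulfonyl Enone

This account rests on a few compounds, and the source may have more. Where it says the series, first, only, none or still open, it means among the compounds named here.

Of the compounds shown here, two have been measured in a functional assay on DU-145 cells (Homo sapiens) for inhibition, read by trypan blue exclusion, with a stated time of 96 h; on this read-out higher numbers stand for weaker inhibition of growth and lower numbers for stronger inhibition of growth. Compound 1 `O=C(/C(=C\c1ccc2ccccc2n1)SCc1ccc(F)cc1)c1ccc(Br)cc1` gives 25000 nM in this assay. Compound 2 `O=C(/C(=C\c1ccc(I)cc1)S(=O)(=O)c1ccc(Br)cc1)c1ccc(Br)cc1` gives 1000 nM in this assay, the lower of the two numbers, and its gap to compound 1 lies beyond the usual scatter of repeated measurements. For the measured compounds named here, these two compounds differ in several places at once, so their numbers show only that compound 2 inhibits growth more strongly, without pointing to any single part of the structure.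

Compound 3 `O=C(/C(=C\c1ccc(Br)cc1)S(=O)(=O)c1ccc(Br)cc1)c1ccc(Br)cc1` has not yet been measured. It differs from compound 2 in one place, (bromo in place of iodo on an aromatic carbon). Going by the values given here, no measured pair shows this change on its own, so nothing here tells how large a step it brings. With no such guide, the expected step from compound 2 to compound 3 in this assay is a 1.2-fold higher number from compound 2 to compound 3 (0.08 log units; within the scatter), that is, none beyond the scatter. Compound 3 is therefore estimated to give about 1200 nM in this assay, within a range from 400 nM to 4000 nM.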

Compound 3, concentration for 50% growth inhibition: 10000 nM
The estimate for compound 3 lay 8.3-fold (0.92 log units) below the measured number; the whole stated range lies below it.
By their numbers in this assay, from the lowest: compound 2; then compound 3; then compound 1.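

In this assay, exchanging 4-iodophenyl for 4-bromophenyl brings a 10-fold higher number from compound 2 to compound 3 (1.00 log units; beyond the scatter), so changing one halogen atom on this ring, para to a large group, is enough to weaken growth inhibition clearly while the rest of the molecule stays the same. Compound 1 and compound 2 differ in several places and could not single out any one part of the structure, whereas this pair marks the position as one where the choice of atom matters. Nothing given here explains why iodo and bromo part so far at this position.

From the compounds shown here alone, it remains open whether a chloro, a methyl or a methoxy group here would fall nearer compound 2 or nearer compound 3, and how an amine would fare. Also open, going by these compounds, is whether the same exchange would bring a step of similar size in a compound built like compound 1.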